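Pyrazolyl enones: removing a methoxy group from compound 1

A few compounds are considered here, and "the series" means these few. Any claim that something is new, unique, unknown or untested is made for them only; others in the source may bear on it.

Measured so far:
compound 1 `COc1cc(-c2cc(/C=C/C(=O)c3ccc(N)cc3)[nH]n2)cc(OC)c1OC`: 3200 nM
compound 2 `COc1ccc(-c2cc(/C=C/C(=O)c3ccc(OC)c(OC)c3)[nH]n2)cc1`: 1570 nM
compound 3 `COc1cc(-c2cc(/C=C/C(=O)c3ccc(Cl)c(Cl)c3)[nH]n2)cc(OC)c1OC`: 24000 nM

In a functional assay on IGROV-1 cells (Homo sapiens) for inhibition, read by sulforhodamine B assay, with a stated time of 48 h (a lower number here means a stronger inhibitor of growth, a higher number a weaker inhibitor of growth), compound 1 gives 3200 nM, the second highest number of the three; compound 2 sits closest, compound 3 furthest. Going by the values given here, the only step within one position, a 7.5-fold higher number from compound 1 to compound 3 (0.88 log units; beyond the scatter), concerns the ring on the carbonyl carbon and so does not bear on the change to compound 4 `COc1ccc(-c2cc(/C=C/C(=O)c3ccc(N)cc3)[nH]n2)cc1OC`, which is hydrogen in place of methoxy on an aromatic carbon. Compound 2, carrying fewer methoxy groups on that ring, gives 1570 nM, but its other ring also differs, so no clean reading of a methoxy removal exists. Compound 4 is therefore expected near compound 1, with a step of a 1.1-fold higher number from compound 1 to compound 4 (0.04 log units; within the scatter) not beyond the scatter, estimated at 3500 nM within 1200 nM to 10000 nM.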

Compound 4, concentration for 50% growth inhibition: 4560 nM
The estimate for compound 4 lay 1.3-fold (0.11 log units) below the measured number; the measured number falls inside the stated range.
By their numbers in this assay, from the lowest: compound 2; then compounds 1 and 4 (each within the scatter of the next); then compound 3.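

In this assay, going by these compounds alone, the step of a 1.4-fold higher number from compound 1 to compound 4 (0.15 log units; within the scatter) is the first reading of a methoxy removal on this ring with the rest of the molecule unchanged, and it lies within the scatter. At this position on the core, hydrogen in place of methoxy therefore gives no change that this assay can resolve. No data at hand bear on why this is so.

From the compounds shown here alone, whether a hydroxyl, an amine or an ethoxy group at this place would read the same remains open. Also open, going by these compounds, is whether the removal reads the same with the 3,4-dichlorophenyl of compound 3 on the carbonyl carbon.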